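Kinetic solubility notes: compound 2 to compound 4

A few compounds are considered here, and "the series" means these few. Any claim that something is new, unique, unknown or untested is made for them only; others in the source may bear on it.

Measured compounds:
compound 1 `CNC(=O)c1cc(C(=O)N[C@H]2[C@@H]3C[C@H](O)C[C@@H]32)n([C@@H](C)c2cccc(Cl)c2)n1`: >= 168 ug/mL
compound 2 `CNC(=O)c1cc(C(=O)N[C@H]2CC[C@H](O)CC2)n([C@@H](C)c2ccc(Cl)cc2)n1`: >= 132 ug/mL
compound 3 `CC(=O)Nc1c(F)cc(C(=O)N[C@H]2CC[C@H](O)CC2)cc1O[C@@H](C)c1ccccc1`: >= 159 ug/mL

All three readings come from a physicochemical assay for solubility, measured as kinetic solubility (on this read-out higher numbers stand for higher solubility and lower numbers for lower solubility), and none of them is a number. For compound 2 the reading >= 132 ug/mL is a limit of the assay (the limit of >= 132 ug/mL in this assay, at which 1 of the 3 values shown sits). For compound 1 the reading >= 168 ug/mL is likewise a limit (the limit of >= 168 ug/mL in this assay, at which 1 of the 3 values shown sits). For compound 3 the reading >= 159 ug/mL is also a limit (the limit of >= 159 ug/mL in this assay, at which 1 of the 3 values shown sits). Compound 2 therefore stands at a limit, as do the two further values shown, so no order among the three can be read from this assay.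

Compound 4 `CNC(=O)c1cc(C(=O)N[C@H]2CC[C@H](O)CC2)n([C@@H](C)c2ccccc2Cl)n1` differs from compound 2 in one place: 2-chlorophenyl in place of 4-chlorophenyl on a saturated chain carbon bound to an aromatic nitrogen and a saturated chain carbon. The two compounds have the same atoms, joined differently. Going by the values given here, no step between measured compounds with this kind of change is available, so there is nothing to size it against.

The expectation for compound 4 is no shift beyond the scatter, a step of a number no higher from compound 2 to compound 4 (the limit leaves the size open) that is essentially flat. Compound 4 is estimated at 132 ug/mL, within 60 ug/mL to 200 ug/mL, and this assay is expected most likely to return a limit again rather than a number.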

Compound 4, solubility: >= 182 ug/mL
Compound 4 was reported as a limit; the forecaster's own chance of this, stated with the estimate: 70%; middle value at least 1.3-fold (0.13 log units) away from the limit.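

In this assay compound 4 gives >= 182 ug/mL, which is a limit. Compound 2 gives >= 132 ug/mL, also a limit, so no step can be read between compound 2 and compound 4. The compounds shown leave open whether 2-chlorophenyl in place of 4-chlorophenyl changes the result in this assay at all, and in which direction.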